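Removing the para fluorine from compound 3's benzyl group

This account rests on a few compounds, and the source may have more. Where it says the series, first, only, none or still open, it means among the compounds named here.

Compound 3 `C=C(Br)C(=O)Nc1cccc(/C=C2\SC(=O)N(Cc3ccc(F)cc3)C2=O)c1` gives the lowest of the two numbers in a functional assay on CCRF-CEM cells (Homo sapiens) for cytotoxicity, read by cell counting, with a stated time of 3 days; a higher number here means a weaker inhibitor, a lower number a stronger inhibitor; the nearest is compound 1 `C=C(Br)C(=O)Nc1cccc(/C=C2\SC(=O)N(Cc3ccc(C(C)(C)C)cc3)C2=O)c1`, which in this assay gives 3000 nM, against 680 nM for compound 3. Among the compounds with values here, the step of a 4.4-fold lower number from compound 1 to compound 3 (0.64 log units; beyond the scatter) is the only step between measured compounds here, and it concerns the group on the benzyl ring. Compound 2 `Nc1cccc(/C=C2\SC(=O)N(Cc3ccccc3)C2=O)c1` carries a plain benzyl group but lacks the bromoacrylamide; in this assay compound 2 reaches only the limit of the assay, > 250000 nM, which is a limit rather than a number (the limit of > 250000 nM in this assay, at which 1 of the 3 values shown sits). Compound 4 `C=C(Br)C(=O)Nc1cccc(/C=C2\SC(=O)N(Cc3ccccc3)C2=O)c1` differs from compound 3 by hydrogen in place of fluoro on an aromatic carbon, on an aromatic carbon of a six-membered aromatic ring of carbon only, para to a large group. Within the data shown here, no measured step removes a fluoro outright, so the step of a 4.4-fold lower number from compound 1 to compound 3 (0.64 log units; beyond the scatter) only shows that this position tolerates a change in group size and that it can move the number by a modest amount. For compound 4 the expected step is a 1.6-fold higher number from compound 3 to compound 4 (0.21 log units; within the scatter), a shift that is expected to stay near the scatter or slightly beyond it toward a higher number. Compound 4 is therefore expected to give about 1100 nM in this assay, within a range from 300 nM to 4000 nM.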

Compound 4, half-maximal inhibitory concentration: 510 nM
For compound 4 the middle estimate is 2.2-fold (0.33 log units) above the measured one; measured number inside the range.
By their numbers in this assay, from the lowest: compounds 4 and 3 (each within the scatter of the next); then compound 1. At a limit, above all of these: compound 2.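

In this assay, a 1.3-fold lower number from compound 3 to compound 4 (0.12 log units; within the scatter) shows that fluoro and hydrogen cannot be told apart on this aromatic carbon, para to a large group, so the fluoro is not needed for the number that compound 3 gives. The earlier step left open whether fluoro itself or the loss of tert-butyl mattered, and a 5.9-fold lower number from compound 1 to compound 4 (0.77 log units; beyond the scatter) places the difference with tert-butyl, since both smaller substituents lie beyond the scatter from compound 1. The plain benzyl pair also gives the first comparison in one place for (1-bromoethenyl)carbonyl in place of hydrogen on a nitrogen on an aromatic ring, an at least 490-fold lower number from compound 2 to compound 4 (2.69 log units; beyond the scatter), and the compound 2 end of that step is a limit of the assay rather than a number: the limit of > 250000 nM in this assay, at which 1 of the 4 values shown sits.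

The compounds shown leave open how this place responds to a methoxy group, an amine or a carboxylic acid, or to a chain of intermediate length between hydrogen and tert-butyl. They also leave open whether a plain acrylamide without the bromine would give a number near that of compound 4.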